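A few compounds are considered here, and "the series" means these few. Any claim that something is new, unique, unknown or untested is made for them only; others in the source may bear on it.

Compound 1 `Oc1ccc(-c2cc(-c3ccc(F)cc3)cc(-c3ccccc3O)n2)cc1` yields no number in a functional assay on HCT-15 cells (Homo sapiens) for inhibition; on this read-out lower numbers stand for stronger inhibition and higher numbers for weaker inhibition: its result is the limit > 50000 nM, the point at which one of the two measured values sits (the limit of > 50000 nM in this assay, at which 1 of the 2 values shown sits). In this assay compound 2 `Oc1ccc(-c2cc(-c3ccc(F)cc3)cc(-c3ccc(O)cc3)n2)cc1` gives 4970 nM. Among the measured compounds shown here, the single measured step, an at least 10-fold lower number from compound 1 to compound 2 (1.00 log units; beyond the scatter), concerns a different position and does not bear on compound 3 `Oc1ccc(-c2cc(-c3ccc(C(F)(F)F)cc3)cc(-c3ccccc3O)n2)cc1`, whose change is trifluoromethyl in place of fluoro on an aromatic carbon. For the measured compounds named here, no measured step touches this position, so no direction can be read from the series, and a compound that starts at a limit is expected to stay near it. Compound 3 is estimated at 50000 nM, between 15000 nM and 200000 nM. The expected step is then a number no higher from compound 1 to compound 3 (the limit leaves the size open).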

Compound 3, half-maximal inhibitory concentration: > 50000 nM
Compound 3: a limit, no number; the forecaster's own chance of this, stated with the estimate: 75%; the middle value sits exactly at the limit.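

Compound 1 and compound 3 both end at a limit in this assay, so no step between them can be read: the limit of > 50000 nM in this assay, at which 2 of the 3 values shown sit.

Going by these compounds, whether trifluoromethyl in place of fluoro changes inhibition in either direction remains open.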